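The source may report more compounds than this note shows. Statements on the series, on what has been measured and on what is new or still open speak of the compounds shown alone.

Measured compounds:
compound 1 `CN(C)CCn1c(N)c(-c2nc3ccccc3[nH]2)c2nc(C#N)c(C#N)nc21`: in a functional assay on A549 cells (Homo sapiens) for antiproliferative activity, read by MTT assay, with a stated time of 48 h (a lower number here means a stronger inhibitor, a higher number a weaker inhibitor), compound 1 reaches only a limit, > 50000 nM.
compound 2 `CCCn1c(N)c(-c2nc3ccccc3[nH]2)c2nc(C#N)c(C#N)nc21`: compound 2 gives 1970 nM.
compound 3 `N#Cc1nc2c(-c3nc4ccccc4[nH]3)c(N)n(CCO)c2nc1C#N`: compound 3 likewise reaches only a limit, > 50000 nM.

For the measured compounds named here, compound 2 holds the only number in this assay; the other two values are limits (the limit of > 50000 nM in this assay, at which 2 of the 3 values shown sit). Compound 4 `N#Cc1nc2c(-c3nc4ccccc4[nH]3)c(N)n(CCCN3CCCCC3)c2nc1C#N` differs from compound 2 by piperidin-1-yl in place of hydrogen on a saturated chain carbon, three bonds along the chain from an aromatic nitrogen. The step that bears on this is an at least 25-fold lower number from compound 1 to compound 2 (1.40 log units; beyond the scatter), where dimethylamino gave way to methyl; an at least 25-fold higher number from compound 2 to compound 3 (1.40 log units; beyond the scatter) also shows a large loss on changing the chain end. Piperidin-1-yl, like dimethylamino in compound 1, carries a nitrogen on the chain, so a large rise in number is expected, a 15-fold higher number from compound 2 to compound 4 (1.18 log units; beyond the scatter), with a fair chance of only a limit. Compound 4 is estimated at 30000 nM, range 6000 nM to 50000 nM.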

Compound 4, half-maximal inhibitory concentration: 6110 nM
For compound 4 the middle estimate is 4.9-fold (0.69 log units) above the measured one, within the range that was stated.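

In this assay, a nitrogen on the chain does not by itself send a compound to the limit: 3-(piperidin-1-yl)propyl in place of propyl costs only a 3.1-fold higher number from compound 2 to compound 4 (0.49 log units; beyond the scatter). The same chain end also stands clear of the two other nitrogen- and hydroxy-bearing chains, with an at least 8.1-fold lower number from compound 3 to compound 4 (0.91 log units; beyond the scatter) and an at least 8.1-fold lower number from compound 1 to compound 4 (0.91 log units; beyond the scatter). Both of those steps rest on a limit rather than a number: the limit of > 50000 nM in this assay, at which 2 of the 4 values shown sit.

On these data alone, compound 4 changes the chain length and the amine together, and the share of each stays open. A 3-(dimethylamino)propyl chain or a 2-(piperidin-1-yl)ethyl chain would separate the two.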